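Replacing a Bromo-Methoxyphenyl Group with a Hydroxyphenyl Group

The source may report more compounds than this note shows. Statements on the series, on what has been measured and on what is new or still open speak of the compounds shown alone.

Among the compounds with values here, compound 1 `COc1ccc(C2=C(c3ccc(SC)cc3)CC3CCCN3C2=O)cc1Br` gives 3000 nM in a functional assay on SK-OV-3 cells (Homo sapiens) for cytotoxicity (a higher number here means a weaker inhibitor of growth, a lower number a stronger inhibitor of growth), the higher of the two numbers measured so far. Compound 2 `CSc1ccc(C2=C(c3ccc(F)c(F)c3)C(=O)N3CCCC3C2)cc1`, carrying a 3,4-difluorophenyl at that position, gives 100 nM in this assay. Compound 3 `CSc1ccc(C2=C(c3ccc(O)cc3)C(=O)N3CCCC3C2)cc1` changes the same position: 4-hydroxyphenyl in place of 3-bromo-4-methoxyphenyl on a double-bonded ring carbon. Within the data shown here, only one measured step bears on this change, and it was large: a 30-fold lower number from compound 1 to compound 2 (1.48 log units; beyond the scatter). Because a 30-fold lower number from compound 1 to compound 2 (1.48 log units; beyond the scatter) shows a sharp drop when the 3-bromo-4-methoxyphenyl is swapped out, a drop beyond the scatter is expected for compound 3 too, of uncertain size, a 5.0-fold lower number from compound 1 to compound 3 (0.70 log units; beyond the scatter). Compound 3 is therefore estimated at 600 nM in this assay, with a range from 150 nM to 2500 nM.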

Compound 3, concentration for 50% growth inhibition: > 100000 nM
Compound 3 gave a limit, no number (the forecaster's own chance of this, stated with the estimate: 2%); at least 160-fold (2.22 log units) between middle value and limit.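

Compound 3 reads at a limit of the assay, not a number: the limit of > 100000 nM in this assay, at which 1 of the 3 values shown sits. The position that gave a 30-fold lower number from compound 1 to compound 2 (1.48 log units; beyond the scatter) also gives an at least 33-fold higher number from compound 1 to compound 3 (1.52 log units; beyond the scatter), so replacing the 3-bromo-4-methoxyphenyl can move the number in this assay in either direction, depending on the group that enters. Exchanging 3,4-difluorophenyl for 4-hydroxyphenyl gives an at least 1000-fold higher number from compound 2 to compound 3 (3.00 log units; beyond the scatter). The compounds shown leave open whether the hydroxyl group alone goes with this large rise, and how a 4-methoxyphenyl or 4-aminophenyl group would read at this position.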